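A few compounds are considered here, and "the series" means these few. Any claim that something is new, unique, unknown or untested is made for them only; others in the source may bear on it.

Measured in a functional assay, with a stated time of 20 min, tested at 2 uM; a lower number here means a weaker effect, a higher number a stronger effect of the compound at the concentration tested:

compound 1 `COc1cc(/C=C/C(=O)C2=C(/C=C/c3ccc(O)c(OC)c3)NC(=O)NC2c2ccc(C)cc2)ccc1O`: 17.2%
compound 2 `COc1cc(/C=C/C(=O)C2=C(/C=C/c3ccc(O)c(OC)c3)NC(=S)NC2c2ccccc2)ccc1O`: 15.5%
compound 3 `COc1cc(/C=C/C(=O)C2=C(/C=C/c3ccc(O)c(OC)c3)NC(=S)NC2c2ccc(C)cc2)ccc1O`: 15.5%

Compound 3 stands level with compound 2 at the digits shown; the two are together the lowest of the three numbers. Compound 1 lies within the scatter of compound 3, so all three values sit in one band and no order can be read among them.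

Going by the values given here, the only step between measured compounds differing in one place is no change at the digits printed from compound 2 to compound 3 (within the scatter), methyl in place of hydrogen on an aromatic carbon, with no change beyond the scatter.

Compound 4 `COc1cc(/C=C/C(=O)C2=C(/C=C/c3ccc(O)c(OC)c3)NC(=S)NC2c2ccccc2O)ccc1O` differs from compound 3 by 2-hydroxyphenyl in place of 4-methylphenyl on a saturated ring carbon. Among the compounds with values here, the one measured step bears on this only loosely: it shows that a change of substituent on the same aryl ring left the value where it was. Within the data shown here, no measured compound carries a hydroxyl on that ring, so its effect is not known. Compound 4 is therefore expected to show no step beyond the scatter, an expected a number 0.5 percentage points higher from compound 3 to compound 4 (within the scatter). The estimate for compound 4 is 16%, with a range from 6% to 28%.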

Compound 4, a percentage reported as activity, at one concentration (the size of the read-out at that concentration, not a potency): 25%
Compound 4: middle estimate off by 9 percentage points, on the low side; the range from low to high includes it.
By their numbers in this assay, from the lowest: compounds 2, 3, 1 and 4 (each within the scatter of the next).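

In this assay, the aryl group on the saturated ring carbon accepts a hydroxyl without a step beyond the scatter: 2-hydroxyphenyl in place of 4-methylphenyl gives a number 9.5 percentage points higher from compound 3 to compound 4 (within the scatter), and a hydroxyl added to the otherwise bare aryl ring gives a number 9.5 percentage points higher from compound 2 to compound 4 (within the scatter). The earlier compounds shown here showed only methyl on this aryl ring, whereas these steps extend the same result to a substituent that brings a hydrogen-bond donor and acceptor, and all four compounds remain one band at this concentration. No supporting data on hand bear on this result.

As far as these compounds go, whether an amine or a carboxylic acid on this aryl ring would stay in that band remains open. Also open, from the compounds shown here alone, is whether a longer alkyl chain in place of the aryl group on the saturated ring carbon would do so.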